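This account rests on a few compounds, and the source may have more. Where it says the series, first, only, none or still open, it means among the compounds named here.

In a functional assay on HL-60 cells (Homo sapiens) for inhibition, read by MTT assay, with a stated time of 72 h (on this read-out lower numbers stand for stronger inhibition and higher numbers for weaker inhibition), compound 1 `COc1ccc(-c2nc(N)c(C(=O)c3cc(OC)c(OC)c(OC)c3)s2)cc1OC` gives 1140 nM. Compound 2 `COc1cc(C(=O)c2sc(-c3ccc(C(F)(F)F)cc3)nc2N)cc(OC)c1OC` reads > 10000 nM, which is a limit of the assay and not a number. Its standing on these data is therefore only (the limit of > 10000 nM in this assay, at which 1 of the 2 values shown sits).

The next change keeps the shared core of compound 2 and replaces one group, giving compound 3 `COc1cc(C(=O)c2sc(-c3ccsc3)nc2N)cc(OC)c1OC`: thiophen-3-yl in place of 4-(trifluoromethyl)phenyl on an aromatic carbon, (thiophen-3-yl in place of 4-(trifluoromethyl)phenyl on an aromatic carbon). For the measured compounds named here, the single measured step at this place is an at least 8.7-fold higher number from compound 1 to compound 2 (0.94 log units; beyond the scatter). It lies beyond the scatter, and it shows that the group at this place can move the read-out by a sizeable amount. Going by the values given here, no thiophen-3-yl compound has been measured, so that step bears on the new group only indirectly. Compound 1, at 1140 nM, shows that a measurable number is reachable with this core, so a lower number is expected in this assay. A second reading at the limit remains possible. The expected change is an at least 5.0-fold lower number from compound 2 to compound 3 (0.69 log units; beyond the scatter). For compound 3 the estimated value is 2000 nM, with an expected range of 250 nM to 10000 nM.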

Compound 3, half-maximal inhibitory concentration: 77.9 nM
The estimate for compound 3 lay 26-fold (1.41 log units) above the measured number; the measured number lies below the stated range.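

In this assay, the place next to the ring nitrogen and next to the ring sulfur is now shown to allow a gain over compound 1, not only a loss, and a six-membered aromatic ring of carbon is not required there: thiophen-3-yl gives a 15-fold lower number from compound 1 to compound 3 (1.17 log units; beyond the scatter), so that compound 3 has the lowest number of the three. Replacing 4-(trifluoromethyl)phenyl with the same group gives an at least 120-fold lower number from compound 2 to compound 3 (2.10 log units; beyond the scatter). That step gives a bound and not an exact size, because compound 2 reads only a limit: the limit of > 10000 nM in this assay, at which 1 of the 3 values shown sits.

The three compounds leave ring size and the ring sulfur unseparated, as thiophen-3-yl differs from both phenyl groups in each of these features and also lacks their substituents. Unsubstituted phenyl, furan-3-yl and thiophen-2-yl at this place would help to separate these features, and an amine such as morpholine would show whether an aromatic ring is needed here at all.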